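A few compounds are considered here, and "the series" means these few. Any claim that something is new, unique, unknown or untested is made for them only; others in the source may bear on it.

Measured compounds in a functional assay on CHO cells for agonist activity at Free fatty acid receptor 1 (Homo sapiens), read by FLIPR and calcium flux; a higher number here means that more compound is needed for the effect, a lower number that less compound is needed:
- compound 1, `CCOc1cc(C)c(-c2cccc(COc3ccc(S(=O)(=O)CC(=O)O)cc3)c2)c(C)c1`: 63.1 nM
- compound 2, `Cc1cc(OCC(C)C)cc(C)c1-c1cccc(COc2ccc(S(=O)(=O)CC(=O)O)cc2)c1`: 95.5 nM

Compound 2 has the higher of the two numbers in this assay, though its gap to compound 1 is within the scatter. Compound 3, `COCCOc1cc(C)c(-c2cccc(COc3ccc(S(=O)(=O)CC(=O)O)cc3)c2)c(C)c1`, is not yet measured; its change from compound 2 is methoxymethyl in place of isopropyl on a saturated chain carbon bound to an oxygen on an aromatic ring. Among the measured compounds shown here, the only step that bears on this position is a 1.5-fold higher number from compound 1 to compound 2 (0.18 log units; within the scatter), which stayed within the scatter. The step to compound 3 is therefore expected to be small as well, a 1.2-fold lower number from compound 2 to compound 3 (0.08 log units; within the scatter). Compound 3 is estimated at 80 nM in this assay, within 30 nM to 250 nM.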

Compound 3, half-maximal effective concentration: 126 nM
Compound 3: the middle estimate sits 1.6-fold (0.20 log units) below what was measured; the measured number falls inside the stated range.
By their numbers in this assay, from the lowest: compounds 1, 2 and 3 (each within the scatter of the next).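

In this assay, among the compounds shown here, the earlier compounds carried only carbon in this chain, whereas methoxymethyl in place of isopropyl brings in an oxygen and a hydrogen-bond acceptor, and gives a 1.3-fold higher number from compound 2 to compound 3 (0.12 log units; within the scatter). Methoxy in place of hydrogen on the ethoxy chain gives a 2.0-fold higher number from compound 1 to compound 3 (0.30 log units; within the scatter), so both changes that introduce this oxygen stay within the scatter. No available evidence explains why these steps are small. The compounds shown leave open whether an amine, a carboxylic acid or a longer chain at this position would also stay within the scatter.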